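Methyl for ethoxy: expected lipophilicity of compound 4

The source may report more compounds than this note shows. Statements on the series, on what has been measured and on what is new or still open speak of the compounds shown alone.

Compound 3 `CCOc1ccc2[nH]c(-c3cccc(OC)c3)c(C3=C(Br)C(=O)NC3=O)c2c1` gives 2.97 in a physicochemical assay for lipophilicity (a higher number here means a more lipophilic compound, a lower number a more polar compound), the highest of the three numbers shown, though the gaps to the other two are within the scatter: compound 2 `COc1ccc(-c2[nH]c3ccc(C)cc3c2C2=C(Br)C(=O)NC2=O)cc1` gives 2.85 and compound 1 `CCOc1ccc2[nH]c(-c3ccc(OC)cc3)c(C3=C(Br)C(=O)NC3=O)c2c1` gives 2.77. Compound 4 `COc1cccc(-c2[nH]c3ccc(C)cc3c2C2=C(Br)C(=O)NC2=O)c1` differs from compound 3 by methyl in place of ethoxy on an aromatic carbon. The same exchange has been made once already in this series, and its outcome was a number 0.08 log units higher from compound 1 to compound 2 (within the scatter). The other measured step, a number 0.20 log units higher from compound 1 to compound 3 (within the scatter), concerns a different part of the molecule and does not bear on the present change. A step beyond the scatter is therefore not expected. The expected step is a number 0.08 log units higher from compound 3 to compound 4 (within the scatter). Compound 4 is estimated at 3.05, with a range from 2.75 to 3.35.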

Compound 4, partition coefficient: 3.12
Beside the measured number, compound 4's estimate is 0.07 log units below it; low and high end bracket the measured number.
By their numbers in this assay, from the lowest: compounds 1, 2, 3 and 4 (each within the scatter of the next, the first and the last beyond it).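

In this assay, methyl in place of ethoxy on an aromatic carbon gives a number 0.15 log units higher from compound 3 to compound 4 (within the scatter), so this exchange now stays within the scatter alongside both 4-methoxyphenyl and 3-methoxyphenyl. The exchange of 4-methoxyphenyl for 3-methoxyphenyl, previously read only with ethoxy present, gives a number 0.27 log units higher from compound 2 to compound 4 (within the scatter), so it also stays within the scatter with methyl at this place. No available measurement accounts for either step.

From the compounds shown here alone, whether an amine or a carboxylic acid at this place would give a step beyond the scatter remains open. So does the result of a longer alkoxy chain there.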